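The source may report more compounds than this note shows. Statements on the series, on what has been measured and on what is new or still open speak of the compounds shown alone.

Measured in a functional assay on the whole organism (strain Wistar) for inhibition, with Rattus norvegicus as the target, read by paw edema, with a stated time of 2 h, at a dose of 10 mg/kg by the intraperitoneal route; on this read-out higher numbers stand for more inhibition at the one dose given (going by the name of the read-out) and lower numbers for less inhibition:
compound 1 `COc1cccc(/C=N/NC(=O)c2cccnc2Nc2cccc(C(F)(F)F)c2)c1` gives 49.7%
compound 2 `COc1ccc(/C=N/NC(=O)c2cccnc2Nc2cccc(C(F)(F)F)c2)cc1OC` gives 49%
compound 3 `O=C(N/N=C/c1cccnc1)c1cccnc1Nc1cccc(C(F)(F)F)c1` gives 62.4%

Compound 1 stands second highest of the three numbers. Its nearest neighbour is compound 2, and the step of a number 0.7 percentage points lower from compound 1 to compound 2 (within the scatter) lies within the scatter, so no order can be read between these two. Compound 3 stands apart from both: a number 12.7 percentage points higher from compound 1 to compound 3 (beyond the scatter) and a number 13.4 percentage points higher from compound 2 to compound 3 (beyond the scatter) are beyond the scatter, though each is modest in size.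

Compound 4 `CNc1ncccc1C(=O)N/N=C/c1cccc(OC)c1` has not yet been measured. It differs from compound 1 in one place: methyl in place of 3-(trifluoromethyl)phenyl on a nitrogen on an aromatic ring. None of the three measured steps bears on this change. All of them alter the group on the carbon with a double bond to nitrogen and leave the nitrogen on the aromatic ring untouched. Among the measured compounds shown here, what they show is only that exchanges at that other end move the read-out by modest amounts. For the measured compounds named here, the change in compound 4 removes the 3-(trifluoromethyl)phenyl group with its ring and puts methyl in its place, a change of a different kind, with no precedent among the measured compounds. The expectation for compound 4 is set somewhat lower, with a wide range, at 38% (18% to 58%). This estimate corresponds to an expected step of a number 11.7 percentage points lower from compound 1 to compound 4 (beyond the scatter).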

Compound 4, a percentage reported as inhibition, in the whole organism at one dose (the size of the read-out at that dose, not a potency): 51.5%
Compound 4: the middle estimate sits 13.5 percentage points below what was measured, within the range that was stated.
By their numbers in this assay, from the lowest: compounds 2, 1 and 4 (each within the scatter of the next); then compound 3.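

The exchange of 3-(trifluoromethyl)phenyl for methyl on the nitrogen on an aromatic ring gives a number 1.8 percentage points higher from compound 1 to compound 4 (within the scatter) in this assay, so this large change in the group leaves no readable difference at the one dose and time given. Among the compounds shown here, the aromatic ring of the leaving group is therefore not needed at this position to reach this level of inhibition, at least with the 3-methoxyphenyl group kept at the other end of the molecule; the earlier steps all changed that other end and could not show this. Nothing at hand explains why the two compounds read alike.

Open, on these data alone, is whether other groups on this nitrogen, such as a longer alkyl chain, a benzyl group or a plain hydrogen, would also stay level with compound 1, and whether the pyridin-3-yl group of compound 3 would keep its step with methyl on that nitrogen. Also open, as far as these compounds go, is whether compound 1 and compound 4 would stay together at other doses or times.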